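The source may report more compounds than this note shows. Statements on the series, on what has been measured and on what is new or still open speak of the compounds shown alone.

In a functional assay on BGC-823 cells (Homo sapiens) for cytotoxicity, read by CCK-8 assay, with a stated time of 24 h (on this read-out lower numbers stand for stronger inhibition and higher numbers for weaker inhibition), compound 1 `C/C(=C\c1cc(-c2ccc(C)cc2)cs1)C(N)=O` has not yet given a number: compound 1 is recorded as > 50000 nM, which is a limit of the assay and not a measured value. Compound 2 `C/C(=C\c1nc(-c2ccc(F)cc2)cs1)C(N)=O` stands in the same place, since in this assay compound 2 is also recorded as > 50000 nM, again a limit. So far the picture is the limit of > 50000 nM in this assay, at which 2 of the 2 values shown sit, with nothing in between to compare against.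

Compound 3 `C=Cc1ccc(-c2csc(/C=C(\C)C(N)=O)c2)cc1` is the next step from compound 1: the change is vinyl in place of methyl on an aromatic carbon. No step between two measured compounds is shown, so nothing fixes the size of this change. The expected step from compound 1 to compound 3 is a number no higher from compound 1 to compound 3 (the limit leaves the size open), meaning no shift beyond the usual scatter. Compound 3 is therefore expected at about 50000 nM in this assay, somewhere between 20000 nM and 200000 nM, most likely reported only as a limit.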

Compound 3, half-maximal inhibitory concentration: > 50000 nM
Compound 3: only a limit was reported (the forecaster's own chance of this, stated with the estimate: 80%); the middle value lies on the limit itself.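

Compound 1 and compound 3 are both recorded only as limits in this assay, so no size can be read for the change from methyl to vinyl: the limit of > 50000 nM in this assay, at which 3 of the 3 values shown sit.

The compounds shown leave open whether any change to this shared core gives a measurable value in this assay.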